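Moving a Ring Substituent: Methyl Out, Bromine In

This account rests on a few compounds, and the source may have more. Where it says the series, first, only, none or still open, it means among the compounds named here.

Of the compounds shown here, two sharing one core have been tested in a functional assay on cells (T-cell, Mus musculus, strain BALB/c) for inhibition, read by MTT assay, with stated times of 24 h and 72 h; a lower number here means a stronger inhibitor, a higher number a weaker inhibitor. Compound 1 `COc1cc(-c2nnc(SCc3ccccc3F)o2)ccc1O` gives 5790 nM. Compound 2 `COc1cc(-c2nnc(SCc3ccccc3C)o2)ccc1O` gives 8420 nM. The step of a 1.5-fold higher number from compound 1 to compound 2 (0.16 log units; within the scatter) lies within the scatter. Compound 2 therefore stands with the higher of the two numbers, but because of a 1.5-fold higher number from compound 1 to compound 2 (0.16 log units; within the scatter) it cannot be told apart from compound 1 with confidence.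

Compound 3 `COc1cc(-c2nnc(SCc3ccc(Br)cc3)o2)ccc1O` is not yet measured. Compared with compound 2 it carries 4-bromophenyl in place of 2-methylphenyl on a saturated chain carbon bound to a sulfur. For the measured compounds named here, no measured step exchanges a methyl for a bromine, and none shifts a substituent from one place on that ring to another; the single step at hand, a 1.5-fold higher number from compound 1 to compound 2 (0.16 log units; within the scatter), concerns a different exchange and stayed within the scatter. On that thin basis no shift beyond the scatter is expected for compound 3. Compound 3 is estimated at 7000 nM, with a range from 2500 nM to 20000 nM. The expected step, a 1.2-fold lower number from compound 2 to compound 3 (0.08 log units; within the scatter), is accordingly one of no real change, with the wide range reflecting how little the data say about this exchange.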

Compound 3, half-maximal inhibitory concentration: 8830 nM
Compound 3: the middle estimate sits 1.3-fold (0.10 log units) below what was measured, and the stated range covers the measured number.
By their numbers in this assay, from the lowest: compounds 1, 2 and 3 (each within the scatter of the next).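

In this assay, 4-bromophenyl in place of 2-methylphenyl on a saturated chain carbon bound to a sulfur gives a step within the scatter (a 1.0-fold higher number from compound 2 to compound 3 (0.02 log units; within the scatter)), and 4-bromophenyl in place of 2-fluorophenyl at that same place does too (a 1.5-fold higher number from compound 1 to compound 3 (0.18 log units; within the scatter)). The earlier step compared two groups with the same name pattern on the ring, whereas these new steps change both the group and its number in the ring's name, and still none of the three compounds can be told apart from the others, so this position has so far accepted every exchange shown. Compound 3 carries both differences at once, so their separate contributions cannot be read, and no measurement at hand offers an explanation for the result.

All the groups shown here are phenyl rings with one small substituent, so it remains open whether an amine or a carboxylic acid on that ring would give a step beyond the scatter. Going by these compounds, it is equally open whether a longer chain or an unsubstituted phenyl at this place would leave the number where it is.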